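The compounds below may be only part of what the source reports. "The series", "measured", "known", "first", "only" and "open" are said of these compounds alone.

Working notes on the series. Going by the values given here, compound 2 `C=C/C=C\[C@H](C)[C@H](OC(N)=O)[C@@H](C)[C@H](O)[C@@H](C)C/C(C)=C\[C@H](C)[C@@H](O)[C@@H](C)/C=C\CCc1cccc(O)c1C` stands in the middle of the three numbers so far in a functional assay on A549 cells (Homo sapiens) for cytotoxicity; a higher number here means a weaker inhibitor, a lower number a stronger inhibitor: compound 2 gives 910 nM. Compound 1 `C=C/C=C\[C@H](C)[C@H](OC(N)=O)[C@@H](C)[C@H](O)[C@@H](C)C/C(C)=C\[C@H](C)[C@@H](O)[C@@H](C)/C=C\CCc1ccc(C)c(F)c1` gives 4000 nM, the weakest inhibitor of the set, and compound 3 `C=C/C=C\[C@H](C)[C@H](OC(N)=O)[C@@H](C)[C@H](O)[C@@H](C)C/C(C)=C\[C@H](C)[C@@H](O)[C@@H](C)/C=C\CCc1ccccc1`, carrying a plain phenyl, gives 510 nM. The measured steps are all swaps of the whole aryl group: a 4.4-fold lower number from compound 1 to compound 2 (0.64 log units; beyond the scatter) and a 7.8-fold lower number from compound 1 to compound 3 (0.89 log units; beyond the scatter) both lie beyond the scatter, whereas a 1.8-fold lower number from compound 2 to compound 3 (0.25 log units; within the scatter) stays within it.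

Compound 4 `C=C/C=C\[C@H](C)[C@H](OC(N)=O)[C@@H](C)[C@H](O)[C@@H](C)C/C(C)=C\[C@H](C)[C@@H](O)[C@@H](C)/C=C\CCc1cccc(O)c1` differs from compound 2 by hydrogen in place of methyl on an aromatic carbon. Among the compounds with values here, no measured step removes the methyl on its own. The step that comes closest is a 1.8-fold lower number from compound 2 to compound 3 (0.25 log units; within the scatter), which takes away both the hydroxy group and the methyl together and still moves no further than the scatter. The two steps from compound 1 show that the aryl substitution pattern can shift the number in this assay, but nothing measured ties that shift to the methyl alone. On that basis the methyl loss in compound 4 is expected to give a step of a 1.2-fold lower number from compound 2 to compound 4 (0.08 log units; within the scatter), that is none beyond the scatter. Compound 4 is estimated at 750 nM, with a range from 300 nM to 1900 nM, pending the measurement.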

Compound 4, half-maximal inhibitory concentration: 190 nM
Beside the measured number, compound 4's estimate is 3.9-fold (0.60 log units) above it; measured number outside the range, below it.
By their numbers in this assay, from the lowest: compound 4; then compounds 3 and 2 (each within the scatter of the next); then compound 1.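

Taken on its own, the methyl on this aromatic carbon, ortho to a hydroxy group, carries a real cost in this assay: hydrogen in its place gives a 4.8-fold lower number from compound 2 to compound 4 (0.68 log units; beyond the scatter), a change that the earlier step from compound 2 to compound 3, where the hydroxy group and the methyl leave together, did not show. The hydroxy group now reads separately as well, since the step between the plain phenyl and 3-hydroxyphenyl is a 2.7-fold lower number from compound 3 to compound 4 (0.43 log units; beyond the scatter), so in this set adding the hydroxy group and adding the methyl move the number in opposite directions, and compound 4 is the strongest inhibitor of the four, with the widest gap being a 21-fold lower number from compound 1 to compound 4 (1.32 log units; beyond the scatter). Nothing in hand gives a reason for either step.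

A 2-methylphenyl compound would show whether the methyl has the same cost without the hydroxy group. As far as these compounds go, it also remains open whether a methoxy group or an amine on that carbon would match the hydroxy group of compound 4, and whether an ethyl or a chlorine in place of the methyl would behave as the methyl does.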